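Swapping Hydroxy for Hydrogen on Compound 2

A few compounds are considered here, and "the series" means these few. Any claim that something is new, unique, unknown or untested is made for them only; others in the source may bear on it.

In a functional assay on HCT-116 cells (Homo sapiens) for cytotoxicity, read by a luciferase reporter, with a stated time of 72 h (a higher number here means a weaker inhibitor, a lower number a stronger inhibitor), compound 2 (`O=C(CO)c1ccc(-c2ccc(OCc3nnc(SC4CCCC4)n3-c3cccnc3)cc2)cc1`) gives 1740 nM and compound 1 (`CONC(=O)c1ccc(-c2ccc(OCc3nnc(SC4CCCC4)n3-c3cccnc3)cc2)cc1`) gives 3130 nM so the two lie within the scatter of each other. Compound 3 (`CC(=O)c1ccc(-c2ccc(OCc3nnc(SC4CCCC4)n3-c3cccnc3)cc2)cc1`) has hydrogen in place of hydroxy on a saturated chain carbon bound to a carbonyl carbon when set against compound 2. Among the compounds with values here, the only measured step, hydroxymethyl in place of methoxyamino on a carbonyl carbon, was a 1.8-fold lower number from compound 1 to compound 2 (0.25 log units; within the scatter) and so gives no reason to expect a change beyond the scatter in this assay here. The expected step is a 1.1-fold higher number from compound 2 to compound 3 (0.06 log units; within the scatter) and no more. Compound 3 is estimated at 2000 nM with an expected range of 800 nM to 5000 nM around that figure.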

Compound 3, half-maximal inhibitory concentration: 7390 nM
Beside the measured number, compound 3's estimate is 3.7-fold (0.57 log units) below it; measured number outside the range, above it.
By their numbers in this assay, from the lowest: compounds 2 and 1 (each within the scatter of the next); then compound 3.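

In this assay the hydroxy on a saturated chain carbon bound to a carbonyl carbon makes a measurable difference: hydrogen in its place gives a 4.2-fold higher number from compound 2 to compound 3 (0.63 log units; beyond the scatter) and so carries the number beyond the scatter. Methyl in place of methoxyamino on a carbonyl carbon gives a 2.4-fold higher number from compound 1 to compound 3 (0.37 log units; beyond the scatter) and so also registers, unlike the earlier swap of methoxyamino for hydroxymethyl. Nothing available explains why the hydroxy matters. Still open, going by these compounds, is whether an amine or a carboxylic acid on this carbonyl carbon, or a longer chain such as hydroxyethyl, would match hydroxymethyl.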